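Thiophen-2-yl replaces naphthalen-2-yl on the amide carbonyl

The source may hold more compounds than are shown below. What is called first, only, known or untested is meant among the compounds shown, and "the series" means these compounds.

Working notes on the series. In a functional assay on HCT-116 cells (Homo sapiens) for antiproliferative activity, read by MTT assay, with a stated time of 72 h (a higher number here means a weaker inhibitor, a lower number a stronger inhibitor), compound 3 `O=C(CSc1cccc(O)c1)Nc1ccc2nc(NC(=O)c3ccc4ccccc4c3)sc2c1` gives 4250 nM, the lowest of the three measured numbers. Compound 2 `CCCC(=O)Nc1nc2ccc(NC(=O)CSc3cccc(O)c3)cc2s1` gives 10600 nM and compound 1 `O=C(CSc1cccc(O)c1)Nc1ccc2nc(NC(=O)c3ccccc3)sc2c1` gives 41000 nM. Both gaps to compound 3 are beyond the scatter: a 2.5-fold lower number from compound 2 to compound 3 (0.40 log units; beyond the scatter) and a 9.6-fold lower number from compound 1 to compound 3 (0.98 log units; beyond the scatter).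

Compound 4 `O=C(CSc1cccc(O)c1)Nc1ccc2nc(NC(=O)c3cccs3)sc2c1` differs from compound 3 only on the carbonyl carbon whose other neighbour is the amide-type nitrogen: thiophen-2-yl in place of naphthalen-2-yl on a carbonyl carbon. Going by the values given here, the steps that bear on this are the ones that vary the same carbonyl substituent. a 9.6-fold lower number from compound 1 to compound 3 (0.98 log units; beyond the scatter) came from going from one six-membered aromatic ring to two fused ones, and a 3.9-fold lower number from compound 1 to compound 2 (0.59 log units; beyond the scatter) shows that a propyl chain also gave a lower number than phenyl. Thiophen-2-yl brings a single five-membered ring, so the change is expected to undo part of the naphthalen-2-yl gain and move the number back toward compound 1, beyond the scatter. The estimated step is a 4.7-fold higher number from compound 3 to compound 4 (0.67 log units; beyond the scatter). Compound 4 is therefore expected at 20000 nM, within a range of 6000 nM to 60000 nM.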

Compound 4, half-maximal inhibitory concentration: 7020 nM
Compound 4: middle estimate off by 2.8-fold (0.45 log units), on the high side; low and high end bracket the measured number.
By their numbers in this assay, from the lowest: compounds 3, 4 and 2 (each within the scatter of the next, the first and the last beyond it); then compound 1.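

In this assay, on the carbonyl carbon whose other neighbour is the amide-type nitrogen, thiophen-2-yl cannot be told apart from naphthalen-2-yl (a 1.7-fold higher number from compound 3 to compound 4 (0.22 log units; within the scatter)) or from propyl (a 1.5-fold lower number from compound 2 to compound 4 (0.18 log units; within the scatter)), whereas phenyl stands apart (a 5.8-fold lower number from compound 1 to compound 4 (0.77 log units; beyond the scatter)). Among these four compounds, a gain at this position therefore does not need two fused rings: one five-membered aromatic ring with a sulfur atom is enough, and compound 1 is the only one outside this group. No measurement available here explains why phenyl differs from the other three groups.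

Still open, going by these compounds, is whether furan-2-yl, another single five-membered ring, would stay with thiophen-2-yl or whether pyridin-3-yl would stay with phenyl. A longer chain such as hexyl would show whether the propyl result extends beyond propyl.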